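The source may report more compounds than this note shows. Statements on the series, on what has been measured and on what is new or still open speak of the compounds shown alone.

Measured so far:
compound 1 `O=C1C(=O)N(CCCCn2cc(COc3cc(=O)oc4ccccc34)nn2)c2ccc(F)cc21` — 77%
compound 2 `O=C1C(=O)N(CCCCCn2cc(COc3cc(=O)oc4ccccc34)nn2)c2ccc(Br)cc21` — 52%

Both numbers come from a functional assay on THP-1 cells (Homo sapiens) for inhibition, read by sulforhodamine B assay, with a stated time of 48 h, tested at 50 uM; a lower number here means less inhibition of growth, a higher number more inhibition of growth at the concentration tested. Compound 1 stands highest of the two. Compound 2 lies lower, and the gap between them is beyond the usual scatter of repeated measurements. Going by the values given here, the two compounds differ in more than one place, so no single-change step can be drawn between them; the gap is read only as what the two values show.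

Compound 3 `O=C1C(=O)N(CCCCn2cc(COc3cc(=O)oc4ccccc34)nn2)c2ccccc21` has not yet been measured. It differs from compound 1 in one place: hydrogen in place of fluoro on an aromatic carbon. Among the compounds with values here, no measured pair in this set isolates that change, so there is no step in hand to read it against. The change is therefore expected to move the number only slightly in this assay, a modest loss of growth inhibition or none beyond the scatter. The expected step is a number 12 percentage points lower from compound 1 to compound 3 (beyond the scatter). For compound 3 the estimate is 65%, with a range from 40% to 85%.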

Compound 3, percent growth inhibition at one concentration: 85%
Estimate against measurement, compound 3: 20 percentage points below; the measured number falls inside the stated range.
By their numbers in this assay, from the lowest: compound 2; then compounds 1 and 3 (each within the scatter of the next).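

This position gives the series its first single-change step: with hydrogen in place of fluoro on the aromatic carbon, this assay shows a number 8 percentage points higher from compound 1 to compound 3 (within the scatter). Within this pair, then, the fluoro is not required for the growth inhibition seen at the concentration tested, and compound 3 keeps that inhibition on the shared core with no substituent at this position, while the values give no order between the two compounds. Nothing in the available data speaks to a cause for this result.

The compounds shown leave open how a methoxy group, an amine or a carboxylic acid on this same aromatic carbon would read in this assay, and so how far this position tolerates anything other than hydrogen or fluoro. The effect of the linking chain also remains open, as compound 2 differs from compound 1 in more than one place and no pair shown isolates the chain, whether shorter or longer.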